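The source may report more compounds than this note shows. Statements on the series, on what has been measured and on what is new or still open speak of the compounds shown alone.

Among the measured compounds shown here, compound 3 `CCOc1ccc2c(=O)cc(C(C)Br)oc2c1CBr` is the one compound here with an actual number in a functional assay on KBVIN cells (Homo sapiens) for antiproliferative activity, read by sulforhodamine B assay, with a stated time of 72 h; a lower number here means a stronger inhibitor of growth, a higher number a weaker inhibitor of growth: it gives 12800 nM. Compound 1 `CCOc1ccc2c(=O)cc(CC)oc2c1CBr` shows only a limit of the assay, > 32100 nM. Compound 2 `CCc1cc(=O)c2ccc(OCC(C)C)c(CBr)c2o1` likewise shows only a limit, > 29400 nM. Between these two the step that the two limits leave unreadable from compound 1 to compound 2 cannot be sized, since both values sit at a limit (the limit of > 29400 nM in this assay, at which 1 of the 3 values shown sits, and (the limit of > 32100 nM in this assay, at which 1 of the 3 values shown sits)). The step of an at least 2.5-fold lower number from compound 1 to compound 3 (0.39 log units; beyond the scatter) is the only readable one.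

Compound 4 `CC(C)COc1ccc2c(=O)cc(C(C)Br)oc2c1CBr` differs from compound 3 by isopropyl in place of methyl on a saturated chain carbon bound to an oxygen on an aromatic ring. For the measured compounds named here, the one measured step of this same kind, from compound 1 to compound 2, gives no readable size, so no step beyond the scatter is expected; the expected step is no change at the digits printed from compound 3 to compound 4 (within the scatter). Compound 4 is therefore estimated at 12800 nM, between 4000 nM and 40000 nM.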

Compound 4, concentration for 50% growth inhibition: 9450 nM
Estimate against measurement, compound 4: 1.4-fold (0.13 log units) above; low and high end bracket the measured number.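

The change from methyl to isopropyl on a saturated chain carbon bound to an oxygen on an aromatic ring, unreadable between two limits before, now has a size in this assay: a 1.4-fold lower number from compound 3 to compound 4 (0.13 log units; within the scatter), so ethoxy and isobutoxy cannot be told apart here. Bromo in place of hydrogen on the other chain carbon gives an at least 3.1-fold lower number from compound 2 to compound 4 (0.49 log units; beyond the scatter), a step read against a limit of the assay. This bromo change thus appears on both cores: the same change on two cores in this assay, an at least 2.5-fold lower number (0.39 log units; beyond the scatter) from compound 1 to compound 3 and an at least 3.1-fold lower number (0.49 log units; beyond the scatter) from compound 2 to compound 4; the limit leaves it open whether they differ.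

From the compounds shown here alone, whether a longer chain or an amine in the place of the isobutyl would keep this level stays open.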